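Shortening the selenium chain on compound 3

The source may hold more compounds than are shown below. What is called first, only, known or untested is meant among the compounds shown, and "the series" means these compounds.

Compound 3 `CCCCC[Se]c1nc(NCc2ccccc2)c2ccccc2n1` stands at the low end of the series: in a functional assay on MCF7 cells (Homo sapiens) for cytotoxicity, read by MTT assay, with a stated time of 72 h (on this read-out lower numbers stand for stronger inhibition of growth and higher numbers for weaker inhibition of growth), compound 3 gives 50 nM, while compound 1 `CCCCC[Se]c1nc(NCc2ccc(SC)cc2)c2ccccc2n1` gives 34700 nM and compound 2 `Sc1nc(NCc2ccccc2)c2ccccc2n1` gives 27200 nM. Both measured steps into compound 3 were large, a 690-fold lower number from compound 1 to compound 3 (2.84 log units; beyond the scatter) and a 540-fold lower number from compound 2 to compound 3 (2.74 log units; beyond the scatter). Compound 4 `C[Se]c1nc(NCc2ccccc2)c2ccccc2n1` differs from compound 3 by hydrogen in place of butyl on a saturated chain carbon bound to a selenium atom, that is pentyl to methyl. Among the compounds with values here, no measured step changes the chain length on the selenium; the nearest is the entry of the whole group in a 540-fold lower number from compound 2 to compound 3 (2.74 log units; beyond the scatter), which marks the group as a main source of the low number. A partial loss of that gain is therefore expected for compound 4, a step of an 8.0-fold higher number from compound 3 to compound 4 (0.90 log units; beyond the scatter) in this assay, with the estimate for compound 4 at 400 nM, between 50 nM and 4000 nM.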

Compound 4, concentration for 50% growth inhibition: 15800 nM
Compound 4: the middle estimate sits 40-fold (1.60 log units) below what was measured; the whole stated range lies below it.
By their numbers in this assay, from the lowest: compound 3; then compounds 4, 2 and 1 (each within the scatter of the next, the first and the last beyond it).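

The length of the chain on the selenium, not just the presence of the group, carries the low number: pentyl to methyl gives a 320-fold higher number from compound 3 to compound 4 (2.50 log units; beyond the scatter) and takes back nearly all of the gain seen on entry of the whole group. The step of a 1.7-fold lower number from compound 2 to compound 4 (0.24 log units; within the scatter) lies within the scatter, so with methyl on the selenium the group cannot be told apart from the single sulfur atom. Nothing measured here accounts for this dependence on the chain.

Still open, going by these compounds, is how the number moves with ethyl, butyl or a longer chain such as hexyl on the selenium. Also open, on these data alone, is whether a pentyl chain on sulfur in place of selenium would keep the low number.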